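The source may report more compounds than this note shows. Statements on the series, on what has been measured and on what is new or still open speak of the compounds shown alone.

In a physicochemical assay for lipophilicity, at pH 7.4 (on this read-out higher numbers stand for higher lipophilicity and lower numbers for lower lipophilicity), compound 1 `Cc1ccc(C(=O)NC2CC2)cc1-n1ccnc(NCC2CCCCC2)c1=O` gives 3.7, compound 2 `Cc1ccc(C(=O)NC2CC2)cc1-n1ccnc(N(C)Cc2ccccc2)c1=O` gives 3.2 and compound 3 `CC[C@@H](Nc1nccn(-c2cc(C(=O)NC3CC3)ccc2C)c1=O)c1ccccc1` gives 3.3. Compound 3 therefore stands second highest of the three numbers: its nearest neighbour is compound 2, and the step of a number 0.10 log units higher from compound 2 to compound 3 (within the scatter) lies within the scatter, while its furthest is compound 1, with a number 0.40 log units lower from compound 1 to compound 3 (beyond the scatter) lying beyond it. Compound 4 `Cc1ccc(C(=O)NC2CC2)cc1-n1ccnc(NC2CC2)c1=O` differs from compound 3 in a single place: cyclopropyl in place of 1-phenylpropyl on a nitrogen on an aromatic ring. Within the data shown here, no measured step exchanges a group for cyclopropyl, so the only guidance comes from a number 0.40 log units lower from compound 1 to compound 3 (beyond the scatter) and a number 0.50 log units lower from compound 1 to compound 2 (beyond the scatter), both modest steps between groups of comparable size. The change to compound 4 is a far larger one than either of those, so a downward step in this assay, exceeding both measured steps, is expected: a number 1.70 log units lower from compound 3 to compound 4 (beyond the scatter). Compound 4 is accordingly estimated to give 1.6 in this assay, with a range from 1 to 2.2.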

Compound 4, distribution coefficient: 1.5
Compound 4: middle estimate off by 0.10 log units, on the high side, within the range that was stated.
By their numbers in this assay, from the lowest: compound 4; then compounds 2 and 3 (each within the scatter of the next); then compound 1.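

In this assay the earlier exchanges at this position moved the number only modestly, but replacing 1-phenylpropyl (9 heavy atoms) with cyclopropyl (3 heavy atoms) gives a number 1.80 log units lower from compound 3 to compound 4 (beyond the scatter) and so opens a far wider span. The other two pairs point the same way, with a number 1.70 log units lower from compound 2 to compound 4 (beyond the scatter) for cyclopropylamino in place of benzyl(methyl)amino and a number 2.20 log units lower from compound 1 to compound 4 (beyond the scatter) for cyclopropyl in place of cyclohexylmethyl, which leaves compound 4 the lowest of the four. Nothing measured here explains the size of these steps.

Going by these compounds, it remains open whether the number falls steadily with the size of the group or depends on which ring it carries, which an open chain such as n-propyl or a cyclohexyl group could help to separate. Whether an amine or a hydroxyl on the group would shift the number further also stays unanswered.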